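Swapping Methoxy for Fluoro: A Cytotoxicity Estimate

The source may report more compounds than this note shows. Statements on the series, on what has been measured and on what is new or still open speak of the compounds shown alone.

Compound 1 `COc1ccccc1-c1cc(=O)c2cc(NC(C)=O)ccc2o1` and compound 2 `CC(=O)Nc1ccc2oc(-c3ccccc3F)cc(=O)c2c1` share one core and differ only in fluoro in place of methoxy on an aromatic carbon. In an ADME assay on MT4 cells (Homo sapiens) for cytotoxicity, read by MTT assay, with a stated time of 4 days (on this read-out lower numbers stand for higher toxicity in this test and higher numbers for lower toxicity in this test), compound 1 gives 226000 nM and compound 2 gives 205000 nM, a step of a 1.1-fold lower number from compound 1 to compound 2 (0.04 log units; within the scatter). Compound 3 `COc1cccc(-c2cc(=O)c3cc(N)ccc3o2)c1` rests on a different core, and the difference between the two cores is not broken down here. In this assay compound 3 gives 247000 nM. Compound 4 `Nc1ccc2oc(-c3cccc(F)c3)cc(=O)c2c1` has not yet been measured; it differs from compound 3 by fluoro in place of methoxy on an aromatic carbon. This is the same kind of change as from compound 1 to compound 2, though the place is not identical: there the fluoro stands ortho to a large group, here meta to a large group. The step of a 1.1-fold lower number from compound 3 to compound 4 (0.04 log units; within the scatter) is expected to be small, because the earlier step of a 1.1-fold lower number from compound 1 to compound 2 (0.04 log units; within the scatter) stayed within the scatter. Compound 4 is therefore estimated at 225000 nM, expected to fall between 120000 nM and 450000 nM.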

Compound 4, half-maximal cytotoxic concentration: 269000 nM
For compound 4 the middle estimate is 1.2-fold (0.08 log units) below the measured one; the measured number falls inside the stated range.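

In this assay, fluoro in place of methoxy gives a 1.1-fold higher number from compound 3 to compound 4 (0.04 log units; within the scatter). Set beside the earlier case, the two steps do not differ: the same change on two cores in this assay, a 1.1-fold lower number (0.04 log units; within the scatter) from compound 1 to compound 2 and a 1.1-fold higher number (0.04 log units; within the scatter) from compound 3 to compound 4, 1.2-fold (0.08 log units) apart, within the scatter of two such steps This shows that, in these two pairs, the change carries from one core to the other without a step beyond the scatter, but it does not show that it would do so on any further core, and the place of the change also differs between the pairs, so place and core cannot be told apart.

The compounds shown leave open how other groups in this place, such as a chlorine atom, a nitrile or an amine, would compare. They also leave open whether any such group would give a step beyond the scatter.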